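This account rests on a few compounds, and the source may have more. Where it says the series, first, only, none or still open, it means among the compounds named here.

Compound 1 `CCCN(CC1CC1)C(=O)c1sc(Nc2c(Cl)cc(Cl)cc2Cl)nc1C`: 360 nM
Compound 2 `CCCN(CCC)C(=O)c1sc(Nc2c(Cl)cc(Cl)cc2Cl)nc1C`: 820 nM

In an assay for displacement of a labelled ligand from corticotropin-releasing factor receptor 1 (Homo sapiens) (on this read-out higher numbers stand for weaker inhibition and lower numbers for stronger inhibition), compound 2 gives the higher of these two numbers, so it is the weaker inhibitor; the step of a 2.3-fold higher number from compound 1 to compound 2 (0.36 log units; beyond the scatter) lies beyond the scatter. Compound 3 `CCCCN(CC)C(=O)c1sc(Nc2c(Cl)cc(Cl)cc2Cl)nc1C` holds the same atoms as compound 2, joined differently: butyl(ethyl)amino in place of dipropylamino on a carbonyl carbon. Within the data shown here, the one measured step, a 2.3-fold higher number from compound 1 to compound 2 (0.36 log units; beyond the scatter), swapped a whole group on the amide-type nitrogen and moved the number only modestly; redistributing chain length between two such groups looks a smaller change, so no step beyond the scatter is expected. Compound 3 is estimated at 800 nM, between 350 nM and 1900 nM, an expected step of a 1.0-fold lower number from compound 2 to compound 3 (0.01 log units; within the scatter).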

Compound 3, inhibition constant: 2800 nM
Compound 3: the middle estimate sits 3.5-fold (0.54 log units) below what was measured, and the stated range ends below it.
By their numbers in this assay, from the lowest: compound 1; then compound 2; then compound 3.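

In this assay, butyl(ethyl)amino in place of dipropylamino gives a 3.4-fold higher number from compound 2 to compound 3 (0.53 log units; beyond the scatter), so this position on the carbonyl carbon responds to how the same atoms are joined, not only to which atoms are present. Replacing (cyclopropylmethyl)(propyl)amino with butyl(ethyl)amino gives the widest gap so far, a 7.8-fold higher number from compound 1 to compound 3 (0.89 log units; beyond the scatter), and the order of the three numbers holds no single trend in chain length. No measurement shown explains this sensitivity. The compounds shown leave open how shorter groups such as diethylamino, or a ring amine such as piperidine, would fare here.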